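A few compounds are considered here, and "the series" means these few. Any claim that something is new, unique, unknown or untested is made for them only; others in the source may bear on it.

The compounds share one core, shown for compound 1 as `O=c1ccc(-c2ccc3cn[nH]c3c2)cn1Cc1cccc(C(F)(F)F)c1`, and differ only in the ring attached through a one-carbon link. In an assay for inhibition of MAP kinase-interacting serine/threonine-protein kinase 2 (Homo sapiens), read by luminescence and ADP-Glo, with a stated time of 2 h (on this read-out lower numbers stand for stronger inhibition and higher numbers for weaker inhibition), compound 1 gives 32 nM. For the measured compounds named here, compound 2, `O=c1ccc(-c2ccc3cn[nH]c3c2)cn1Cc1ccccc1`, gives 75 nM in this assay, the higher of the two numbers so far; the step of a 2.3-fold higher number from compound 1 to compound 2 (0.37 log units; beyond the scatter) is the only measured step in this set. Compound 3, `NC(=O)c1ccc(Cn2cc(-c3ccc4cn[nH]c4c3)ccc2=O)cc1`, is not yet measured; its change from compound 2 is carbamoyl in place of hydrogen on an aromatic carbon. Going by the values given here, no measured step puts a carbamoyl onto this ring, so the only step that bears on it is the one from compound 1 to compound 2, which shows that a change on this ring can shift the number modestly. A carbamoyl could move the number by a similar amount in either direction. For compound 3 the step of a 1.5-fold lower number from compound 2 to compound 3 (0.18 log units; within the scatter) is therefore expected. Compound 3 is estimated at 50 nM in this assay, with a range from 15 nM to 200 nM.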

Compound 3, half-maximal inhibitory concentration: > 2000 nM
Compound 3: no number, only a limit (the forecaster's own chance of this, stated with the estimate: 3%); at least 40-fold (1.60 log units) between middle value and limit.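

Compound 3 gives no number in this assay, only a limit: the limit of > 2000 nM in this assay, at which 1 of the 3 values shown sits. Putting carbamoyl on the aromatic carbon para to a large group gives an at least 26-fold higher number from compound 2 to compound 3 (1.42 log units; beyond the scatter), and the true size of this step cannot be read beyond that limit. For the compounds shown here, the only earlier step on this ring, a 2.3-fold higher number from compound 1 to compound 2 (0.37 log units; beyond the scatter), was modest, so this result adds something new: one group on this ring can weaken inhibition far more than that step suggested.

The compounds shown leave open whether the large step belongs to carbamoyl itself or to its place on the ring, as carbamoyl appears at only this one place. They also leave open how a nitrile, an amine or a carboxylic acid at the same place would compare with carbamoyl.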